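The source may report more compounds than this note shows. Statements on the series, on what has been measured and on what is new or still open speak of the compounds shown alone.

Measured compounds in an assay on isolated protein for binding affinity to histamine H2 receptor (Homo sapiens); a lower number here means a stronger inhibitor, a higher number a weaker inhibitor:

Compound 1, `CCCCCC(=O)c1ccc(OCCCN2CCNCC2)cc1`, gives 14500 nM.
Compound 2, `CCCCCC(=O)c1ccc(OCCCN2CCN(C(=O)OC)CC2)cc1`, gives 12000 nM.
Compound 3, `CCCCCC(=O)c1ccc(OCCCN2CCN(C(=O)N3CCOCC3)CC2)cc1`, gives 17800 nM.

All three share one core and differ only in what sits on an amine nitrogen in a ring. Compound 3 carries the (morpholin-4-yl)carbonyl there; its numbers sit close to the others, with a 1.2-fold higher number from compound 1 to compound 3 (0.09 log units; within the scatter) and a 1.5-fold higher number from compound 2 to compound 3 (0.17 log units; within the scatter), so the three values cannot be told apart with confidence.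

Compound 4, `CCCCCC(=O)c1ccc(OCCCN2CCN(C(=O)c3c[nH]cn3)CC2)cc1`, has not yet been measured in this assay. It differs from compound 3 in one place: 1H-imidazol-4-yl in place of morpholin-4-yl on a carbonyl carbon. Two measured steps speak to this position. The change from hydrogen to a carbonyl-bearing group gave a 1.2-fold lower number from compound 1 to compound 2 (0.08 log units; within the scatter), and exchanging one group on that carbonyl carbon for another gave a 1.5-fold higher number from compound 2 to compound 3 (0.17 log units; within the scatter). Neither moved the number beyond the scatter, so a further exchange on the same carbonyl carbon is expected to leave the number where it stands, in no clear direction.

Compound 4 is therefore estimated at 15000 nM, within a range of 7000 nM to 35000 nM, which means an expected step of a 1.2-fold lower number from compound 3 to compound 4 (0.07 log units; within the scatter).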

Compound 4, inhibition constant: 19500 nM
Compound 4: middle estimate off by 1.3-fold (0.11 log units), on the low side, within the range that was stated.
By their numbers in this assay, from the lowest: compounds 2, 1, 3 and 4 (each within the scatter of the next).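

In this assay, the position now holds an aromatic ring on the carbonyl carbon: 1H-imidazol-4-yl, a five-membered ring with 1 hydrogen-bond donor, replaces morpholin-4-yl, a six-membered non-aromatic ring with 0 hydrogen-bond donors, and the result is a 1.1-fold higher number from compound 3 to compound 4 (0.04 log units; within the scatter). The new group also stays within reach of the methoxy group on the same carbonyl carbon, at a 1.6-fold higher number from compound 2 to compound 4 (0.21 log units; within the scatter), and of the plain hydrogen on the amine nitrogen in a ring, at a 1.3-fold higher number from compound 1 to compound 4 (0.13 log units; within the scatter), so all four compounds remain indistinguishable despite these differences in ring type and donor count. No supporting measurement bears on this result, so the data offer no explanation for it.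

The compounds shown leave open whether a benzyl or a simple methyl group placed directly on that amine nitrogen, with no carbonyl, would shift the number beyond the scatter. Going by these compounds, it is equally open whether a carboxylic acid or a primary amine carried on a longer chain from the carbonyl carbon would do so, since every group so far has left the number effectively unmoved.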